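Two Chlorines Enter the Aryl Ring of a Cyclic Imide

A few compounds are considered here, and "the series" means these few. Any claim that something is new, unique, unknown or untested is made for them only; others in the source may bear on it.

Compound 1 `CC1(c2ccccc2)CC(=O)N(CC(=O)N2CCN(c3ccccc3F)CC2)C1=O`: 300 mg/kg
Compound 2 `Cc1cccc(N2CCN(C(=O)CN3C(=O)CC(C)(c4ccccc4)C3=O)CC2)c1`: "not active" (no number reported)
Compound 3 `CC1(c2ccccc2)CC(=O)N(CC(=O)N2CCN(c3ccccc3)CC2)C1=O`: 300 mg/kg

In a functional assay on the whole organism (strain CD-1) with Mus musculus as the target, with a stated time of 2 h (a higher number here means that more compound is needed for the effect, a lower number that less compound is needed), compound 3 gives 300 mg/kg, level with compound 1, since the step of no change at the digits printed from compound 1 to compound 3 (within the scatter) stays within the scatter. Compound 2, which carries a methyl on the aryl ring instead, is reported as "not active" (no number reported), with no number. Compound 4 `CC1(c2ccccc2)CC(=O)N(CC(=O)N2CCN(c3cccc(Cl)c3Cl)CC2)C1=O` is not yet measured. It differs from compound 3 by 2,3-dichlorophenyl in place of phenyl on an amine nitrogen in a ring. For the measured compounds named here, only one measured step bears on this, the hydrogen-for-fluoro exchange in no change at the digits printed from compound 1 to compound 3 (within the scatter), which changed nothing beyond the scatter; compound 2 warns that a different aryl substituent can abolish activity. On this thin basis compound 4 is expected at 300 mg/kg, within 100 mg/kg to 1000 mg/kg, a step of no change at the digits printed from compound 3 to compound 4 (within the scatter) that is estimated to stay within the scatter.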

Compound 4, minimum effective dose: "not active" (no number reported)
For compound 4 the study gives words and no number, so the estimate cannot be set against anything.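

Compound 4 is reported in words alone, so no step from compound 3 to compound 4 can be read, and no measurement shown here accounts for the result. Going by these compounds, whether any aryl substituent on the shared core reduces the dose needed remains open.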